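Pyrazole chalcones: dichloro to dimethoxy on the carbonyl side

A few compounds are considered here, and "the series" means these few. Any claim that something is new, unique, unknown or untested is made for them only; others in the source may bear on it.

Three compounds in this series have numbers in a functional assay on PC-3 cells (Homo sapiens) for cytotoxicity, read by sulforhodamine B assay, with a stated time of 48 h, tested at 1 uM; a lower number here means a stronger effect, a higher number a weaker effect of the compound at the concentration tested. Compound 1 `COc1ccc(-c2cc(/C=C/C(=O)c3ccc(OC)c(OC)c3)[nH]n2)cc1` gives 71%, compound 2 `COc1cc(-c2cc(/C=C/C(=O)c3ccc(Cl)c(Cl)c3)[nH]n2)cc(OC)c1OC` gives 87%, and compound 3 `COc1ccc(-c2cc(/C=C/C(=O)c3cc(OC)c(OC)c(OC)c3)[nH]n2)cc1OC` gives 71%. Compound 2 stands highest of the three, and its gap to each of compound 1 and compound 3 lies beyond the scatter, so compound 2 shows the weakest effect of the measured set in this assay.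

Compound 4 `COc1ccc(C(=O)/C=C/c2cc(-c3cc(OC)c(OC)c(OC)c3)n[nH]2)cc1OC` has not been measured. Its structure differs from compound 2 in one place: 3,4-dimethoxyphenyl in place of 3,4-dichlorophenyl on a carbonyl carbon. Among the compounds with values here, no step between measured compounds is on hand for this exact change, so only the spread of the measured numbers can guide the expectation.

The two measured compounds that carry a methoxy-bearing aryl on the carbonyl side, compound 1 and compound 3, both sit well below compound 2. On that basis a step downward beyond the scatter is expected from compound 2 to compound 4, of about a number 14 percentage points lower from compound 2 to compound 4 (beyond the scatter). Compound 4 is estimated at 73% in this assay, with a range from 60% to 86%, because compound 1 gives 71% and compound 3 gives 71% with dimethoxy- or trimethoxyphenyl in that same position.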

Compound 4, a percentage reported as activity, at one concentration (the size of the read-out at that concentration, not a potency): 71%
For compound 4 the middle estimate is 2 percentage points above the measured one, within the range that was stated.
By their numbers in this assay, from the lowest: compounds 1, 3 and 4 (each within the scatter of the next); then compound 2.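

In this assay, within the data shown here, 3,4-dimethoxyphenyl in place of 3,4-dichlorophenyl on a carbonyl carbon gives a number 16 percentage points lower from compound 2 to compound 4 (beyond the scatter), the first direct reading of this change with the rest of the structure held constant, and it shows that this position alone can shift the read-out. Compound 4 shares its 3,4-dimethoxyphenyl on a carbonyl carbon with compound 1 and differs from it in one other place; compound 1 gives 71% and compound 4 gives 71%, within the scatter of each other. Nothing on hand explains the step.

Going by these compounds, how a phenyl carrying a dimethylamino group or a carboxylic acid would read at this position remains open. Also open, on these data alone, is whether the step from 3,4-dichlorophenyl to 3,4-dimethoxyphenyl recurs on the core of compound 1.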